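This account rests on a few compounds, and the source may have more. Where it says the series, first, only, none or still open, it means among the compounds named here.

Of the compounds shown here, three of one shared core have been tested in a functional assay on MCF7 cells (Homo sapiens) for inhibition, read by sulforhodamine B assay; on this read-out lower numbers stand for stronger inhibition and higher numbers for weaker inhibition. Compound 1 `O=C1C(Nc2ccccc2F)=CC(=O)c2c1nc1n2[C@H]2OC[C@@H](O)[C@H]2OC1` reaches only a limit in this assay, > 4000 nM, and not a number. Compound 3 `O=C1C(N2CCCCC2)=CC(=O)c2c1nc1n2[C@H]2OC[C@@H](O)[C@H]2OC1` likewise gives only a limit, > 8000 nM. Among the measured compounds shown here, compound 2 `O=C1C=C(Nc2ccccc2F)C(=O)c2c1nc1n2[C@H]2OC[C@@H](O)[C@H]2OC1` is the one compound with a number: in this assay compound 2 gives 3640 nM. Where compound 2 stands against compound 1 and compound 3 cannot be read. For the measured compounds named here, the one step between measured compounds that differ in a single place, a step that the two limits leave unreadable from compound 1 to compound 3, cannot be read because the limit of > 4000 nM in this assay, at which 1 of the 3 values shown sits, and the limit of > 8000 nM in this assay, at which 1 of the 3 values shown sits, cap both of its ends.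

Compound 4 `O=C1C=C(Nc2ccc(I)cc2)C(=O)c2c1nc1n2[C@H]2OC[C@@H](O)[C@H]2OC1` has not been measured. It differs from compound 2 in one place: 4-iodophenyl in place of 2-fluorophenyl on an amine nitrogen. Going by the values given here, no measured step touches this kind of change, as the only step in the set concerns piperidin-1-yl in place of (2-fluorophenyl)amino on a double-bonded ring carbon and is itself unreadable. Among the compounds with values here, with nothing among the measured compounds that speaks for a shift in either direction, no step beyond the usual scatter is expected. The step is estimated at a 1.0-fold lower number from compound 2 to compound 4 (0.02 log units; within the scatter). Compound 4 is therefore expected to give about 3500 nM in this assay, within a range from 1200 nM to 10000 nM, with a real chance that only a limit is reported.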

Compound 4, half-maximal inhibitory concentration: 2230 nM
Estimate against measurement, compound 4: 1.6-fold (0.20 log units) above; measured number inside the range.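

Among the compounds shown here, the change from 2-fluorophenyl to 4-iodophenyl on an amine nitrogen gives the first step in this set that can be read in this assay: a 1.6-fold lower number from compound 2 to compound 4 (0.21 log units; within the scatter). It shows that on an amine nitrogen whose other neighbour is a double-bonded ring carbon, exchanging one halogen-bearing phenyl ring for the other, with the fluorine at the 2 position and the iodine at the 4 position of their names, keeps the read-out within the scatter, and that both compound 2 and compound 4 give numbers rather than limits. Nothing among the measured compounds offers a reason for the size of this step.

As far as these compounds go, the step exchanges the halogen and its place on the ring together, so the effect of each alone stays open, and 4-fluorophenyl or 2-iodophenyl on the same nitrogen would separate the two. Also open, from the compounds shown here alone, is whether a phenyl ring carrying a carboxylic acid or an amine, or a longer chain on this nitrogen, would move the number beyond the scatter.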